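From bromo to trifluoromethyl in compound 1

The source may report more compounds than this note shows. Statements on the series, on what has been measured and on what is new or still open speak of the compounds shown alone.

In a functional assay on MCF7 cells (Homo sapiens) for inhibition, read by sulforhodamine B assay (a lower number here means a stronger inhibitor, a higher number a weaker inhibitor), the values are as follows:
Compound 1 `O=C1C(Nc2ccc(Br)cc2)=CC(=O)c2c1nc1n2[C@H]2OC[C@@H](O)[C@H]2OC1` gives 4330 nM
Compound 2 `O=C1C(N2CCCC2)=CC(=O)c2c1nc1n2[C@H]2OC[C@@H](O)[C@H]2OC1` gives > 16000 nM as a limit
Compound 3 `O=C1C(N2CCCCC2)=CC(=O)c2c1nc1n2[C@H]2OC[C@@H](O)[C@H]2OC1` gives > 8000 nM as a limit

Compound 1 alone has a number here, the other two values being limits. Compound 4 `O=C1C(Nc2ccc(C(F)(F)F)cc2)=CC(=O)c2c1nc1n2[C@H]2OC[C@@H](O)[C@H]2OC1` carries trifluoromethyl in place of bromo on an aromatic carbon. Going by the values given here, no measured step makes this change. Among the compounds with values here, the only measured steps from compound 1 replace the whole (4-bromophenyl)amino group (an at least 3.6-fold higher number from compound 1 to compound 2 (0.56 log units; beyond the scatter); an at least 1.8-fold higher number from compound 1 to compound 3 (0.26 log units; that floor lies within the scatter)). Compound 4 keeps the aromatic ring those steps remove, so no step beyond the scatter is expected from compound 1 in this assay. Compound 1 gives 4330 nM as the starting point. The expected change is small (a 1.1-fold lower number from compound 1 to compound 4 (0.03 log units; within the scatter)). For compound 4 the estimate is 4000 nM with an expected range from 1800 nM to 9500 nM in this measurement.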

Compound 4, half-maximal inhibitory concentration: > 4000 nM
Compound 4 gave a limit, no number; the forecaster's own chance of this, stated with the estimate: 10%; the middle value lies on the limit itself.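

In this assay compound 4 gives > 4000 nM, which is a limit and not a number, and the step between compound 1 and compound 4 cannot be read. The compounds shown leave open whether trifluoromethyl in place of bromo changes the inhibition at all.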